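From 4-Fluorophenyl to 4-Methylphenyl in Compound 4

The source may report more compounds than this note shows. Statements on the series, on what has been measured and on what is new or still open speak of the compounds shown alone.

compound 1 `Cc1ccc2ncc(S(=O)(=O)c3ccc(F)cc3)c(N3CCC(C)CC3)c2c1`: 90%
compound 2 `CC1CCN(c2c(S(=O)(=O)c3ccc(F)cc3)cnc3ccc(Cl)cc23)CC1`: 89%
compound 3 `COc1ccc2ncc(S(=O)(=O)c3ccc(F)cc3)c(N3CCC(C)CC3)c2c1`: 27%

In an assay on isolated protein for displacement of a labelled ligand from metabotropic glutamate receptor 5 (Homo sapiens), with a stated time of 60 min, tested at 1 uM (a lower number here means less inhibition, a higher number more inhibition at the concentration tested (going by the name of the read-out)), compound 2 gives 89%, the second highest of the three numbers. Its nearest neighbour is compound 1, separated by a number 1 percentage points lower from compound 1 to compound 2 (within the scatter). Compound 3 sits far below both: a number 63 percentage points lower from compound 1 to compound 3 (beyond the scatter) and a number 62 percentage points lower from compound 2 to compound 3 (beyond the scatter).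

Compound 4 `Cc1ccc(S(=O)(=O)c2cnc3ccc(Cl)cc3c2N2CCC(C)CC2)cc1` differs from compound 2 in one place: methyl in place of fluoro on an aromatic carbon. Every measured step, by contrast, concerns a substituent on the shared core, not the 4-fluorophenyl group, so none of them bears directly on this change. Going by the values given here, the only guide is that compound 1 and compound 2 sit close together in this assay while a single change on the core moved compound 3 far down.

Among the compounds with values here, with no measured step on the 4-fluorophenyl ring, the estimate for compound 4 in this assay is 80%, between 55% and 95%, meaning an expected step of a number 9 percentage points lower from compound 2 to compound 4 (within the scatter) that is not expected to reach beyond the scatter.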

Compound 4, a percentage reported as inhibition, at one concentration (the size of the read-out at that concentration, not a potency): 95%
Estimate against measurement, compound 4: 15 percentage points below; the measured number falls inside the stated range.
By their numbers in this assay, from the lowest: compound 3; then compounds 2, 1 and 4 (each within the scatter of the next).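

Going by these compounds alone, this is the first measured change on the 4-fluorophenyl group rather than on a substituent of the shared core: in this assay, methyl in place of fluoro gives a number 6 percentage points higher from compound 2 to compound 4 (within the scatter). At this position, para to a large group, the two substituents therefore cannot be told apart in this read-out, and the high number of compound 2 does not depend on the fluoro group being present. No data shown explain why the two groups read alike.

On these data alone, whether the number would hold with an amine, a carboxylic acid or a longer chain at this position remains open. As far as these compounds go, it is also open whether the 4-methylphenyl group would behave the same way with methyl or methoxy rather than chloro on the core.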